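Saturating the side chain of compound 2

The compounds below may be only part of what the source reports. "The series", "measured", "known", "first", "only" and "open" are said of these compounds alone.

Compound 1 `C/C=C(\C)C(=O)Oc1cc(C)ccc1C1(COC(C)=O)CO1` gives 8320 nM
Compound 2 `C=C(COC(C)=O)c1ccc(C)cc1OC(=O)/C(C)=C/C` gives 8500 nM

Both compounds were tested in a functional assay on cells (Neutrophil, Homo sapiens) for inhibition, with a stated time of 5 min (on this read-out lower numbers stand for stronger inhibition and higher numbers for weaker inhibition), and the two values lie within the usual scatter of each other. Compound 2 at 8500 nM therefore stands level with compound 1 at 8320 nM on these numbers.

The next compound to be tested is compound 3 `C/C=C(\C)C(=O)Oc1cc(C)ccc1C(C)COC(C)=O` and it departs from compound 2 in one place. The change is 1-(acetoxymethyl)ethyl in place of 1-(acetoxymethyl)ethenyl on an aromatic carbon with 1-(acetoxymethyl)ethyl in place of 1-(acetoxymethyl)ethenyl on an aromatic carbon, ortho to the ((1-methylprop-1-en-1-yl)carbonyl)oxy group and para to the methyl group.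

For the measured compounds named here, no pair of measured compounds differs in one place, so the data hold no direct measure of such a change. Starting from compound 2 at 8500 nM a small step in this assay is expected, within the scatter and, if anything, towards a slightly higher number. The estimated change is a 1.2-fold higher number from compound 2 to compound 3 (0.07 log units; within the scatter) and it would leave the two compounds hard to tell apart. Compound 3 is expected to read 10000 nM within an estimated range from 4000 nM to 25000 nM in this assay once tested.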

Compound 3, half-maximal inhibitory concentration: 18400 nM
Estimate against measurement, compound 3: 1.8-fold (0.26 log units) below; measured number inside the range.
By their numbers in this assay, from the lowest: compounds 1 and 2 (each within the scatter of the next); then compound 3.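

For the compounds shown here, putting 1-(acetoxymethyl)ethyl in place of 1-(acetoxymethyl)ethenyl, on the aromatic carbon ortho to the ((1-methylprop-1-en-1-yl)carbonyl)oxy group and para to the methyl group, gives a 2.2-fold higher number from compound 2 to compound 3 (0.34 log units; beyond the scatter) in this assay and so provides the first measured single-place step in this set, modest in size but beyond the scatter. The entering and leaving groups match in heavy atoms and hydrogen-bond acceptors and differ by one double bond outside aromatic rings, so this position is shown to register a change as small as saturating that double bond, and in the direction of weaker inhibition. Nothing measured here accounts for why the number moves.

The compounds shown leave open whether the acetoxy part of this side chain matters at this position, for example whether a free hydroxymethyl group or a longer chain would read differently. They also leave open whether the same saturation step would keep its size if the ((1-methylprop-1-en-1-yl)carbonyl)oxy group gave way to a simple acetoxy group.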